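This account rests on a few compounds, and the source may have more. Where it says the series, first, only, none or still open, it means among the compounds named here.

Series notes, read-out a functional assay on PC-3 cells (Homo sapiens) for cytotoxicity, read by MTT assay, with a stated time of 72 h; on this read-out lower numbers stand for stronger inhibition and higher numbers for weaker inhibition:
- compound 1 `CNC(=O)c1cc(Oc2ccc(C(=O)/C=C/c3ccco3)cc2)ccn1` gives "not determined" (no result reported)
- compound 2 `CNC(=O)c1cc(Oc2ccc(C(=O)/C=C/c3ccc([N+](=O)[O-])cc3)cc2)ccn1` gives 11100 nM
- compound 3 `CNC(=O)c1cc(Oc2ccc(C(=O)/C=C/c3ccccc3)cc2)ccn1` gives 3170 nM

Of the two numbers available, compound 3 has the lower, and compound 1 offers no number for comparison. The next candidate is compound 4 `CNC(=O)c1cc(Oc2ccc(C(=O)/C=C/c3ccc(Cl)cc3Cl)cc2)ccn1`, with the change (2,4-dichlorophenyl in place of phenyl on a double-bonded chain carbon bound to a double-bonded chain carbon). Going by the values given here, one measured step bears on this: a 3.5-fold lower number from compound 2 to compound 3 (0.54 log units; beyond the scatter), which is modest. Among the compounds with values here, no measured compound carries 2,4-dichlorophenyl, so that step supports only a modest expected size and gives no firm direction. The expected move is a 1.1-fold higher number from compound 3 to compound 4 (0.04 log units; within the scatter), and it may not exceed the scatter. Compound 4 is estimated at 3500 nM, with an expected range of 1200 nM to 10000 nM.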

Compound 4, half-maximal inhibitory concentration: 9220 nM
Estimate against measurement, compound 4: 2.6-fold (0.42 log units) below, and the stated range covers the measured number.
By their numbers in this assay, from the lowest: compound 3; then compounds 4 and 2 (each within the scatter of the next).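

In this assay, 2,4-dichlorophenyl on this double-bonded chain carbon gives no gain over phenyl, with a 2.9-fold higher number from compound 3 to compound 4 (0.46 log units; beyond the scatter), so phenyl keeps the lowest number of the three. The two substituted phenyl groups do not separate, with a 1.2-fold lower number from compound 2 to compound 4 (0.08 log units; within the scatter), and both stand above the unsubstituted phenyl of compound 3. Nothing available accounts for this rise.

From the compounds shown here alone, whether a single chlorine or a methoxy group on the phenyl would also raise the number stays open. So does the effect of a dimethylamino group here.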